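This account rests on a few compounds, and the source may have more. Where it says the series, first, only, none or still open, it means among the compounds named here.

Of the compounds shown here, three built on one shared core have been tested in a functional assay on PC-3 cells (Homo sapiens) for cytotoxicity, read by MTT assay, with a stated time of 48 h; a higher number here means a weaker inhibitor, a lower number a stronger inhibitor. Compound 1 `COc1cc(-c2nnc3n2NC(c2cccs2)C(C(=O)c2ccc(F)cc2)S3)cc(OC)c1OC` gives 27400 nM in this assay. Compound 3 `COc1cc(-c2nnc3n2NC(c2cccs2)C(C(=O)c2ccc(Cl)cc2)S3)cc(OC)c1OC` gives 32500 nM in this assay, and the step of a 1.2-fold higher number from compound 1 to compound 3 (0.07 log units; within the scatter) lies within the scatter, so these two values cannot be told apart. Compound 2 `COc1cc(-c2nnc3n2NC(c2ccco2)C(C(=O)c2ccccc2F)S3)cc(OC)c1OC` reaches only a limit of this assay, > 100000 nM, which is not a number. Compound 2 therefore stands at the weak end of what has been seen so far, while compound 1 and compound 3 have measurable values.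

Compound 4 `COc1cc(C(=O)C2Sc3nnc(-c4cc(OC)c(OC)c(OC)c4)n3NC2c2ccco2)cc(OC)c1OC` has not yet been measured. It differs from compound 2 in one place: 3,4,5-trimethoxyphenyl in place of 2-fluorophenyl on a carbonyl carbon. For the measured compounds named here, the only measured step at that carbonyl carbon is a 1.2-fold higher number from compound 1 to compound 3 (0.07 log units; within the scatter), a halogen swap that stays within the scatter; it says nothing about exchanging the whole 2-fluorophenyl for 3,4,5-trimethoxyphenyl. The starting point is itself (the limit of > 100000 nM in this assay, at which 1 of the 3 values shown sits). The direction and size of the step in this assay are therefore open, and a limit may again be all that is reported. Compound 4 is expected to give about 60000 nM, with a range from 15000 nM to 300000 nM. That estimate corresponds to the expected step of an at least 1.6-fold lower number from compound 2 to compound 4 (0.22 log units; that floor lies within the scatter).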

Compound 4, half-maximal inhibitory concentration: 52200 nM
For compound 4 the middle estimate is 1.1-fold (0.06 log units) above the measured one; the measured number falls inside the stated range.
By their numbers in this assay, from the lowest: compounds 1, 3 and 4 (each within the scatter of the next). At a limit, above all of these: compound 2.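

In this assay, the carbonyl carbon can now be read for the exchange of a whole aromatic group and not only for a halogen swap: the change to 3,4,5-trimethoxyphenyl gives an at least 1.9-fold lower number from compound 2 to compound 4 (0.28 log units; that floor lies within the scatter). The entering group is clearly the larger one, with 12 heavy atoms against 7 and 3 hydrogen-bond acceptors against 0, and with it at this position compound 4 still gives a measurable value of 52200 nM. Compound 2 remains a limit and not a number, so that step is only a floor and its true size is unknown: the limit of > 100000 nM in this assay, at which 1 of the 4 values shown sits.

The compounds shown cannot say which part of the exchange matters, the loss of the fluorine or the arrival of the three methoxy groups, and whether a plain phenyl, or a phenyl carrying an amine or a carboxylic acid, would also give a measurable value remains open. Also open, from the compounds shown here alone, is whether the same exchange would act in the same way on compound 1 or compound 3, which carry a different ring elsewhere on the shared core.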